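The compounds below may be only part of what the source reports. "The series", "measured", "known", "first", "only" and "open" are said of these compounds alone.

Measured compounds
compound 1 `C=CCc1cc(OC)c(OC(C)C(O[C@@H]2C[C@H](C)CC[C@H]2C(C)C)c2ccc(O)c(OC)c2)c(OC)c1` gives 28 nM
compound 2 `C=CCc1cc(OC)c(OC(C)C(OCC)c2ccc(O)c(OC)c2)c(OC)c1` gives 332 nM
compound 3 `C=CCc1cc(OC)c(OC(C)C(OC(C)C)c2ccc(O)c(OC)c2)c(OC)c1` gives 82 nM

In an assay on HEK293 cells for agonist activity at transient receptor potential cation channel subfamily M member 8 (Homo sapiens), read by fluorescence and calcium flux, with a stated time of 5 min (a lower number here means that less compound is needed, a higher number that more compound is needed for the effect), compound 2 has the highest number of the three. The step of a 12-fold higher number from compound 1 to compound 2 (1.07 log units; beyond the scatter) is the largest gap in the set, and the step of a 4.0-fold lower number from compound 2 to compound 3 (0.61 log units; beyond the scatter) shows a modest change in the other direction. Compound 1 sits lowest; compound 3 lies between the two.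

Compound 4 `C=CCc1cc(OC)c(O[C@@H](C)[C@H](OCC)c2ccc(O)c(OC)c2)c(OC)c1` is still to be measured. The change from compound 2 to compound 4 is the two compounds have the same atoms and bonds; at least one stereo element is drawn with a configuration in one of them and without one in the other: 2 of 2 stereo elements differ; a stereocentre at a saturated chain carbon is drawn without a configuration in compound 2 and S in compound 4; a stereocentre at a saturated chain carbon is drawn without a configuration in compound 2 and R in compound 4. No atom leaves and none enters; compound 4 is a single drawn stereoisomer of the material measured as compound 2.

Going by the values given here, none of the measured steps bears on this change: a 12-fold higher number from compound 1 to compound 2 (1.07 log units; beyond the scatter) and a 4.0-fold lower number from compound 2 to compound 3 (0.61 log units; beyond the scatter) both alter the alkoxy group on the saturated carbon, not the configuration, and no pair of measured compounds differs in configuration alone. The data give no basis for the direction of the step. A single stereoisomer may give a number somewhat lower or higher than the unresolved material, so a small step is expected, with wide uncertainty.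

Compound 4 is estimated at 250 nM, range 80 nM to 1000 nM, which is expected to mean a step of a 1.3-fold lower number from compound 2 to compound 4 (0.12 log units; within the scatter).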

Compound 4, half-maximal effective concentration: 1130 nM
The estimate for compound 4 lay 4.5-fold (0.66 log units) below the measured number; measured number outside the range, above it.
By their numbers in this assay, from the lowest: compound 1; then compound 3; then compound 2; then compound 4.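

In this assay, going by these compounds alone, a 3.4-fold higher number from compound 2 to compound 4 (0.53 log units; beyond the scatter) is the first step in which no atom leaves or enters, and it lies beyond the scatter, so the drawing of the two saturated chain carbons matters in its own right and not only the alkoxy group that the earlier steps varied. The only difference to which this step can be put down is the following: the fact that one of compounds 2 and 4 is drawn with a defined configuration and the other without, at the place where they differ. Within the data shown here, the number for compound 2 therefore cannot be taken as the number of the single stereoisomer drawn as compound 4, and the unresolved ethyl compound, like compounds 1 and 3 with the same two carbons undrawn, has to be read as material of undefined configuration at these carbons.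

Still open, as far as these compounds go, is whether any other stereoisomer at these two carbons gives a number lower than that of compound 2, and whether a configuration step of similar size holds with isopropyl or 2-isopropyl-5-methylcyclohexyl on the oxygen. Also open, from the compounds shown here alone, is how a longer chain such as n-butyl, or an amine carried on that chain, would behave at this oxygen once the configuration is fixed.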